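A few compounds are considered here, and "the series" means these few. Any claim that something is new, unique, unknown or untested is made for them only; others in the source may bear on it.

In a functional assay on HL-60 cells (Homo sapiens) for cytotoxicity, read by MTT assay, with a stated time of 72 h (on this read-out higher numbers stand for weaker inhibition and lower numbers for stronger inhibition), compound 2 `O=C(Nc1nnc(-c2ccc(O)c(O)c2)s1)c1ccc(Cl)cc1` gives 14700 nM, the second highest of three numbers. Compound 1 `O=C(Nc1nnc(-c2cccc(O)c2O)s1)C1CCCCC1` gives 7900 nM in this assay, a gap within the scatter, while compound 3 `CC(=O)Nc1nnc(-c2cccc(O)c2O)s1` gives 49000 nM, further off and beyond the scatter. Compound 4 `O=C(Nc1nnc(-c2ccc(O)c(O)c2)s1)c1ccccc1` differs from compound 2 in one place: hydrogen in place of chloro on an aromatic carbon. Among the measured compounds shown here, the only measured step between two closely related structures, a 6.2-fold higher number from compound 1 to compound 3 (0.79 log units; beyond the scatter), concerns the group on the carbonyl carbon rather than the aromatic ring, so it does not bear on swapping chloro for hydrogen. The data give no direct guide for this change. A shift that stays within the scatter is therefore expected: a 1.2-fold higher number from compound 2 to compound 4 (0.09 log units; within the scatter). Compound 4 is estimated at 18000 nM, with a range from 7000 nM to 45000 nM.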

Compound 4, half-maximal inhibitory concentration: 17600 nM
Estimate against measurement, compound 4: 1.0-fold (0.01 log units) above; the measured number falls inside the stated range.
By their numbers in this assay, from the lowest: compounds 1, 2 and 4 (each within the scatter of the next, the first and the last beyond it); then compound 3.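

In this assay, going from 4-chlorophenyl to phenyl gives a 1.2-fold higher number from compound 2 to compound 4 (0.08 log units; within the scatter), so at this place, para to a large group, the chloro can be lost without a shift that stands out from the scatter. Among the compounds shown here, this is the first view of a change on this aromatic ring, as the earlier step concerned the group on the carbonyl carbon. Nothing available explains why compound 2 and compound 4 match. A single swap cannot show whether a larger group at this place, such as methoxy, an amine or a carboxylic acid, would also leave the number in place.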